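The compounds below may be only part of what the source reports. "The series", "measured", "known", "first", "only" and "open" are said of these compounds alone.

Measured in a toxicity assay on HepG2 cells (Homo sapiens) for inhibition, read by resazurin assay, with a stated time of 24 h; on this read-out lower numbers stand for higher toxicity in this test and higher numbers for lower toxicity in this test:
- compound 1 `Cn1c([N+](=O)[O-])cnc1C(=O)N1CCCC1`: > 100000 nM (a limit)
- compound 2 `O=C(NCc1cccc(OC(F)(F)F)c1)c1ncc([N+](=O)[O-])[nH]1`: > 100000 nM (a limit)
- compound 3 `O=C(c1ncc([N+](=O)[O-])[nH]1)N1CCCC1`: > 100000 nM (a limit)

No number has been measured so far in this assay. Every result is the limit of > 100000 nM in this assay, at which 3 of the 3 values shown sit. For the measured compounds named here, compound 3 therefore stands at > 100000 nM, which is a limit and not a number, level with the other two compounds on the only reading available.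

Compound 4 `CNC(=O)c1ncc([N+](=O)[O-])[nH]1` carries methylamino in place of pyrrolidin-1-yl on a carbonyl carbon.

Going by the values given here, no measured step covers this change. Among the compounds with values here, the one step available, a step that the two limits leave unreadable from compound 1 to compound 3, concerns a different place and gives no size to carry over. Compound 2 also has an amide hydrogen, and it gives > 100000 nM, again a limit.

With all results at the limit of > 100000 nM in this assay, at which 3 of the 3 values shown sit, no step beyond the scatter is expected, in either direction. The expected change is a step that the limit leaves unreadable from compound 3 to compound 4. The estimate for compound 4 is 120000 nM, with an expected range of 50000 nM to 300000 nM.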

Compound 4, half-maximal cytotoxic concentration: > 100000 nM
Compound 4 ended at the assay's limit (the forecaster's own chance of this, stated with the estimate: 90%); the middle value is on the limit's open side.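

No step can be read from compound 3 to compound 4, as both results are limits: the limit of > 100000 nM in this assay, at which 4 of the 4 values shown sit.

The compounds shown leave open whether any structure in this series reaches a numerical reading in this assay, and so whether methylamino in place of pyrrolidin-1-yl changes that reading at all.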